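The source may report more compounds than this note shows. Statements on the series, on what has been measured and on what is new or still open speak of the compounds shown alone.

Measured in an ADME assay on L6 cells (Rattus norvegicus) for inhibition, read by resazurin assay, with a stated time of 72 h; a higher number here means a weaker inhibitor, a lower number a stronger inhibitor:
- compound 1 `CNc1nc(NC)c2ncn([C@@H]3O[C@H](C)[C@@H](O)[C@H]3O)c2n1` gives 187000 nM
- compound 2 `CNc1nc(Cl)c2ncn([C@@H]3O[C@H](C)[C@@H](O)[C@H]3O)c2n1` gives 175000 nM

Compound 1 has only compound 2 to be compared with, and the two lie within the scatter of each other, so neither ranks ahead. The next compound, compound 3 `CNc1nc(N)nc2c1ncn2[C@@H]1O[C@H](C)[C@@H](O)[C@H]1O`, has not yet been measured. It carries hydrogen in place of methyl on a nitrogen on an aromatic ring, so one methylamino of compound 1 becomes amino (hydrogen in place of methyl on a nitrogen on an aromatic ring).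

For the measured compounds named here, only one measured step bears on this: a 1.1-fold lower number from compound 1 to compound 2 (0.03 log units; within the scatter). There, compound 2 carries chloro where compound 1 carries methylamino. That step touches the other methylamino group of compound 1, so it is indirect evidence, and a single step is thin support. Still, swapping a whole methylamino group left the number unmoved beyond the scatter, and the change to compound 3 is smaller in atoms. No step beyond the scatter is therefore expected in this assay, in either direction.

The expected change is a 1.1-fold lower number from compound 1 to compound 3 (0.04 log units; within the scatter).

For compound 3 the estimated value is 170000 nM, with an expected range from 70000 nM to 350000 nM.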

Compound 3, half-maximal inhibitory concentration: 211000 nM
Compound 3: the middle estimate sits 1.2-fold (0.09 log units) below what was measured, within the range that was stated.
By their numbers in this assay, from the lowest: compounds 2, 1 and 3 (each within the scatter of the next).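

In this assay, cutting methylamino back to amino on this nitrogen gives a 1.1-fold higher number from compound 1 to compound 3 (0.05 log units; within the scatter), so losing this one methyl leaves the reading within the scatter. For the compounds shown here, this is the first direct look at this methylamino group, as the earlier step replaced the other methylamino group of compound 1 with chloro, and that step also stayed within the scatter; each of the two groups has therefore now been changed once, with no step beyond the scatter in this assay. Nothing measured here explains why the methyl makes no visible difference, so the result stands as an observation only.

Still open, on these data alone, is whether a larger replacement on this nitrogen, such as a longer chain like propyl or a second methyl to give dimethylamino, would shift the number beyond the scatter. All three compounds also keep the rest of the core the same, so what would follow from a change there, such as an amine in place of a hydroxyl, remains an open question.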